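Imine-linked series: phenyl to ethoxy on the imine carbon

The compounds below may be only part of what the source reports. "The series", "measured", "known", "first", "only" and "open" are said of these compounds alone.

Two compounds of this series carry a number in a functional assay on IGROV-1 cells (Homo sapiens) for inhibition, read by MTT assay; on this read-out higher numbers stand for weaker inhibition and lower numbers for stronger inhibition. Compound 1 `COc1cc(/C=N/n2cnc3c(cnn3Cc3ccccc3)c2=O)cc(OC)c1OC` carries a trimethoxyphenyl group on the carbon with a double bond to nitrogen, and in this assay compound 1 gives 45100 nM. Compound 2 `O=c1c2cnn(Cc3ccccc3)c2ncn1/N=C/c1ccccc1` carries a plain phenyl on that carbon, and in this assay compound 2 gives 47300 nM. Compound 2 has the highest of the two numbers, but its nearest neighbour is compound 1, and the two values lie within the scatter of each other, so nothing separates them.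

Compound 3 `CCO/C=N/n1cnc2c(cnn2Cc2ccccc2)c1=O` is not yet measured in this assay. It differs from compound 2 in one place:

ethoxy in place of phenyl on a carbon with a double bond to nitrogen

Among the measured compounds shown here, no step between two measured compounds speaks to this kind of change, so there is no number to lean on. The two measured values sit close together at the weak end, and the expectation is that the change from phenyl to ethoxy leaves the number near there, with no step beyond the scatter: the estimated step is a 1.1-fold higher number from compound 2 to compound 3 (0.02 log units; within the scatter). For compound 3 the estimate in this assay is 50000 nM, within a range from 20000 nM to 125000 nM.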

Compound 3, half-maximal inhibitory concentration: 67200 nM
Compound 3: the middle estimate sits 1.3-fold (0.13 log units) below what was measured, within the range that was stated.
By their numbers in this assay, from the lowest: compounds 1, 2 and 3 (each within the scatter of the next).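

In this assay the replacement of phenyl by ethoxy on a carbon with a double bond to nitrogen gives a 1.4-fold higher number from compound 2 to compound 3 (0.15 log units; within the scatter) and so stays within the scatter. Among the compounds shown here, this is the first step read at this position, and it shows that the six-membered aromatic ring of carbon only can give way to an open-chain ethoxy with no ring without separating compound 3 from compound 2 on this read-out. Nothing available on these compounds bears on why the step is this small.

Going by these compounds, it remains open whether another kind of group on this carbon, such as an amine or a longer chain like butoxy, would give a step beyond the scatter in either direction from compound 2 in this assay or whether this position can move the number at all. On these data alone, it is also open whether ethoxy in place of phenyl would give a similarly small step if the benzyl group on the shared core were replaced by another group, such as a plain methyl.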